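This account rests on a few compounds, and the source may have more. Where it says the series, first, only, none or still open, it means among the compounds named here.

Measured in an ADME assay on MT4 cells (Homo sapiens) for cytotoxicity, read by MTT assay, with a stated time of 96 h; on this read-out lower numbers stand for higher toxicity in this test and higher numbers for lower toxicity in this test:

- Compound 1 `NS(=O)(=O)c1ccc(N2N=C(c3ccccc3)CC2c2ccccc2F)cc1` gives 42000 nM
- Compound 2 `NS(=O)(=O)c1ccc(N2N=C(c3ccc(OCc4ccccc4)cc3)CC2c2ccc(F)cc2)cc1` gives > 100000 nM
- Compound 3 `NS(=O)(=O)c1ccc(N2N=C(c3ccc(Oc4ccccc4)cc3)CC2c2ccccc2)cc1` gives 42000 nM

Compound 2 gives > 100000 nM, which is a limit of the assay and not a number. Its true position is therefore open on the upper side, and it cannot be placed exactly against the other two compounds. For the measured compounds named here, compound 1 gives 42000 nM and compound 3 gives 42000 nM, and these are the only actual numbers in the set.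

Compound 4 `NS(=O)(=O)c1ccc(N2N=C(c3ccc(OCc4ccccc4)cc3)CC2c2ccc(Cl)cc2)cc1` keeps the frame of compound 2 and has chloro in place of fluoro on an aromatic carbon, para to a large group, so that 4-fluorophenyl becomes 4-chlorophenyl (chloro in place of fluoro on an aromatic carbon). Going by the values given here, no two measured compounds differ in one place only, so no measured step gives the size of this change.

In this assay a small move toward lower numbers is expected, or none beyond the scatter. The expected size is an at least 1.2-fold lower number from compound 2 to compound 4 (0.09 log units; that floor lies within the scatter). The low end of the range is set by compound 1 with 42000 nM and compound 3 with 42000 nM. For compound 4 the estimated value is 80000 nM, with an expected range from 40000 nM to 120000 nM.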

Compound 4, half-maximal cytotoxic concentration: 70000 nM
The estimate for compound 4 lay 1.1-fold (0.06 log units) above the measured number, within the range that was stated.
By their numbers in this assay, from the lowest: compounds 1, 3 and 4 (each within the scatter of the next). At a limit, above all of these: compound 2.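

In this assay, compound 4 gives 70000 nM, so the frame of compound 2 now carries an actual number, with chloro on an aromatic carbon para to a large group. Compound 2 gives > 100000 nM, which is a limit of the assay and not a number. The change from 4-fluorophenyl to 4-chlorophenyl therefore reads only as a floor, an at least 1.4-fold lower number from compound 2 to compound 4 (0.15 log units; that floor lies within the scatter), and this first one-place step in the series fixes no true size, leaving open whether the change moves the number beyond the scatter at all: the limit of > 100000 nM in this assay, at which 1 of the 4 values shown sits.

The compounds shown hold only fluoro and chloro at this position in this frame, so how the read-out responds to a group such as methoxy, an amine or a carboxylic acid there remains open. The step also stands as a single pair, and whether the same change of fluoro to chloro gives a similar result on another frame of the series, or at another place on this ring, cannot be told from these compounds.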